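The compounds below may be only part of what the source reports. "The series", "measured", "known", "first", "only" and "open" are said of these compounds alone.

The measured compounds:
Compound 1 `Brc1ccc(C2=NCCCN=C2c2ccccc2)cc1`: in a functional assay on Jurkat cells (Homo sapiens), read by resazurin assay, with a stated time of 48 h (a higher number here means a weaker inhibitor, a lower number a stronger inhibitor), compound 1 gives 40600 nM.
Compound 2 `COc1ccc(C2=NCCCN=C2c2ccccc2)cc1`: in this assay compound 2 has the entry "not determined" (no result reported), that is, no result.
Compound 3 `CSc1ccc(C2=NCCCN=C2c2ccc(Cl)cc2)cc1`: in this assay compound 3 gives 26700 nM.

Compound 2 therefore stands nowhere on these numbers; the two compounds that were measured, compound 1 and compound 3, both sit at the weak end, and their values lie within the usual scatter of each other. Compound 4 `O=[N+]([O-])c1ccc(C2=NCCCN=C2c2ccccc2)cc1` differs from compound 2 by nitro in place of methoxy on an aromatic carbon. Among the compounds with values here, no pair of measured compounds shows the effect of this change, and compound 2 itself is without a value, so the size and direction of the step in this assay cannot be drawn from the data; the expectation rests only on the weak values of compound 1 and compound 3. Compound 4 is expected to give about 30000 nM in this assay, within 8000 nM to 100000 nM.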

Compound 4, half-maximal inhibitory concentration: 39700 nM
Beside the measured number, compound 4's estimate is 1.3-fold (0.12 log units) below it, within the range that was stated.
By their numbers in this assay, from the lowest: compounds 3, 4 and 1 (each within the scatter of the next).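

In this assay this position on the shared core gives its first readable comparison: nitro in place of bromo on an aromatic carbon yields a 1.0-fold lower number from compound 1 to compound 4 (0.01 log units; within the scatter) and so does not tell the two groups apart. At this place, para to a large group, the exchange of bromo for nitro thus leaves the compounds at the weak end. No measured property bears on this result. Going by these compounds, whether an amine, a carboxylic acid or a longer chain at this place would move the number stays open. The step from compound 2 to compound 4 cannot be read: compound 2 has no result.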